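The source may report more compounds than this note shows. Statements on the series, on what has been measured and on what is new or still open speak of the compounds shown alone.

In an ADME assay on MCF-10A cells (Homo sapiens) for cytotoxicity, read by MTT assay, with a stated time of 72 h (a higher number here means a weaker inhibitor, a lower number a stronger inhibitor), three compounds built on a shared core have been measured. Compound 1 `Cc1ccc(-c2ccc(C)n2-c2ccc(-c3nc4ccc(F)cc4s3)cc2)cc1` gives 33600 nM. Compound 2 `COc1ccc2nc(-c3ccc(-n4c(C)ccc4-c4ccc(C)cc4)cc3)sc2c1` gives 34000 nM, and compound 3 `COc1ccc2nc(-c3ccc(-n4c(C)ccc4-c4ccc(F)cc4)cc3)sc2c1` gives 38300 nM. The step of a 1.0-fold higher number from compound 1 to compound 2 (0.01 log units; within the scatter) comes from methoxy in place of fluoro on an aromatic carbon. The step of a 1.1-fold higher number from compound 2 to compound 3 (0.05 log units; within the scatter) comes from a fluoro in place of a methyl on an aromatic carbon. How the core of compound 3 differs from the core of compound 1 is not broken down here.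

Compound 4 `COc1ccc(-c2ccc(C)n2-c2ccc(-c3nc4ccc(OC)cc4s3)cc2)cc1` has not yet been measured in this assay. It differs from compound 3 by methoxy in place of fluoro on an aromatic carbon. Among the compounds with values here, this is the same kind of change as the one made from compound 1 to compound 2, though the place is not the same: in the earlier case the aromatic carbon is part of a fused or bridged system of two rings, meta to a fused ring and para to a fused ring, whereas here it sits on a six-membered aromatic ring of carbon only, para to a large group. Because the earlier change gave a 1.0-fold higher number from compound 1 to compound 2 (0.01 log units; within the scatter), compound 4 is expected to move little, with an estimated step of a 1.0-fold lower number from compound 3 to compound 4 (0.00 log units; within the scatter). Compound 4 is estimated at 38000 nM, between 19000 nM and 76000 nM.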

Compound 4, half-maximal inhibitory concentration: 30600 nM
Estimate against measurement, compound 4: 1.2-fold (0.09 log units) above, and the stated range covers the measured number.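

In this assay, the change from 4-fluorophenyl to 4-methoxyphenyl gives a 1.3-fold lower number from compound 3 to compound 4 (0.10 log units; within the scatter), and replacing methyl with methoxy gives a 1.1-fold lower number from compound 2 to compound 4 (0.05 log units; within the scatter). Methoxy in place of fluoro therefore carries over between the two cores without a difference that can be told from the scatter: the same change on two cores in this assay, a 1.0-fold higher number (0.01 log units; within the scatter) from compound 1 to compound 2 and a 1.3-fold lower number (0.10 log units; within the scatter) from compound 3 to compound 4, 1.3-fold (0.10 log units) apart, within the scatter of two such steps. Within the data shown here, this shows only that the change stays small in these two cases, which lie at different places on the molecule; it does not show that the change would stay small on any other core, and it gives no ranking of fluoro, methyl and methoxy.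

The compounds shown carry only fluoro, methyl and methoxy at these places, so it remains open whether an amine, a carboxylic acid or a longer chain there would shift the number in this assay. Also open, going by these compounds, is whether the same small steps would appear in any other cell type.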